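Ethyl in Place of Methoxy on the Fused Ring

The source may report more compounds than this note shows. Statements on the series, on what has been measured and on what is new or still open speak of the compounds shown alone.

Four compounds share one core bearing a methylpiperazine. In a functional assay on ileum (strain Hartley) for agonist activity at 5-hydroxytryptamine receptor 3A (Cavia porcellus) (a lower number here means a less potent compound, a higher number a more potent compound, by a factor of ten per unit of this negative logarithm), compound 1 `CCc1cc(C)cc2nc(N3CCN(C)CC3)oc12` gives 6.46, and compound 2 `CN1CCN(c2nc3cccc(Cl)c3o2)CC1` gives 5.5. Compound 3 `COc1cccc2nc(N3CCN(C)CC3)oc12` reaches only the assay limit of < 4, a limit and not a number (the limit of < 4 in this assay, at which 1 of the 3 values shown sits). Going by the values given here, the one measured step at this place, a number at least 1.50 log units lower from compound 2 to compound 3 (beyond the scatter), was methoxy in place of chloro on an aromatic carbon. Compound 4 `CCc1cccc2nc(N3CCN(C)CC3)oc12` differs from compound 3 by ethyl in place of methoxy on an aromatic carbon. Since compound 1 carries ethyl there with 6.46, the step of a number at least 2.00 log units higher from compound 3 to compound 4 (beyond the scatter) is expected to be large and upward. Compound 4 is estimated at 6, between 5 and 6.8.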

Compound 4, negative logarithm of the half-maximal effective concentration: 5.48
For compound 4 the middle estimate is 0.52 log units above the measured one; the measured number falls inside the stated range.
By their numbers in this assay, from the lowest: compounds 4 and 2 (each within the scatter of the next); then compound 1. At a limit, below all of these: compound 3.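

Compound 3 stands at a limit of the assay and not at a number: the limit of < 4 in this assay, at which 1 of the 4 values shown sits. In this assay, ethyl in place of methoxy gives a number at least 1.48 log units higher from compound 3 to compound 4 (beyond the scatter), while ethyl in place of chloro gives a number 0.02 log units lower from compound 2 to compound 4 (within the scatter), so at this position ethyl and chloro cannot be told apart and methoxy alone stands off from them. Hydrogen in place of methyl on an aromatic carbon gives a number 0.98 log units lower from compound 1 to compound 4 (beyond the scatter), so the step to compound 1 comes from a change elsewhere on the ring.

Going by these compounds, what an amine, a hydroxyl or a longer chain such as propyl would do at this position remains open.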